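A few compounds are considered here, and "the series" means these few. Any claim that something is new, unique, unknown or untested is made for them only; others in the source may bear on it.

Measured in a functional assay on NALM-6 cells (Homo sapiens); on this read-out higher numbers stand for weaker inhibition and lower numbers for stronger inhibition:
compound 1 `CCSC[C@H](NC(C)=O)C(=O)CCl` gives 52800 nM
compound 2 `CCCCCCCCSC[C@H](NC(C)=O)C(=O)CCl` gives 5600 nM

Compound 2 holds the lower of these two numbers. Among the measured compounds shown here, the single measured step, a 9.4-fold lower number from compound 1 to compound 2 (0.97 log units; beyond the scatter), came from lengthening the chain that carries the sulfur. Compound 3 `CCCCCCCCCCCCSC[C@H](NC(C)=O)C(=O)CCl` differs from compound 2 by butyl in place of hydrogen on a saturated chain carbon, eight bonds along the chain from a sulfur. For the measured compounds named here, only that earlier step bears on this change; it was modest, and the present extension adds a shorter chain piece. A smaller drop in this assay is therefore expected, estimated at a 2.8-fold lower number from compound 2 to compound 3 (0.45 log units; beyond the scatter). For compound 3 the expected value is 2000 nM, with a likely range from 700 nM to 6000 nM.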

Compound 3, half-maximal inhibitory concentration: 2000 nM
Beside the measured number, compound 3's estimate shows no gap at the digits printed; the measured number falls inside the stated range.
By their numbers in this assay, from the lowest: compound 3; then compound 2; then compound 1.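

Extending the chain further still pays in this assay: butyl in place of hydrogen, eight bonds along the chain from a sulfur, gives a 2.8-fold lower number from compound 2 to compound 3 (0.45 log units; beyond the scatter), so the gain seen in a 9.4-fold lower number from compound 1 to compound 2 (0.97 log units; beyond the scatter) does not stop at compound 2. Across these three compounds, each longer chain carries the lower number, and none goes against this. Nothing measured here explains the trend.

From the compounds shown here alone, whether a longer chain would lower the number further remains open. So does the effect of an amine or a carboxylic acid at the chain end.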